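The compounds below may be only part of what the source reports. "The series", "measured", "known", "first", "only" and "open" are said of these compounds alone.

Measured so far in an ADME assay on microsomes from liver (Rattus norvegicus) for metabolic stability; a higher number here means that the compound lasts longer, a lower number that the compound disappears faster:
Compound 1 `CC(C)[C@@H](C[C@H]1SC(=O)NC1=O)c1ccc(-c2ccc3cccc(F)c3c2)[nH]c1=O` gives 0.77 h.
Compound 2 `CC(C)(/C=C1\OC(=O)NC1=O)c1ccc(-c2ccc3cccc(F)c3c2)[nH]c1=O` gives a reading that is a limit of the assay, > 3 h.
Compound 3 `CC(C)C(c1ccc(-c2ccc3cccc(F)c3c2)[nH]c1=O)C1SC(=O)NC1=O` gives 0.76 h.

Compound 3 holds the lower of the two numbers, with compound 1 the nearest; the two lie within the usual scatter, so no order between them is claimed. The third reading, that of compound 2, is not a number but (the limit of > 3 h in this assay, at which 1 of the 3 values shown sits).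

Compound 4 `CC(C)C(/C=C1\SC(=O)NC1=O)c1ccc(-c2ccc3cccc(F)c3c2)[nH]c1=O` is not yet measured. It differs from compound 3 in one place: a group of 8 heavy atoms (4 carbon, 1 nitrogen, 2 oxygen, 1 sulfur; one five-membered non-aromatic ring with 2 hetero atoms) in place of a group of 7 heavy atoms (3 carbon, 1 nitrogen, 2 oxygen, 1 sulfur; one five-membered non-aromatic ring with 2 hetero atoms), on a saturated chain carbon bound to an aromatic carbon and a saturated chain carbon. Within the data shown here, no step between measured compounds isolates this change, so its size cannot be read from the numbers. Compound 2, whose ring group likewise carries a double bond outside aromatic rings, is the compound whose reading sits at the limit, and that is the only pointer toward direction. The step from compound 3 to compound 4 is expected to be upward, a 2.6-fold higher number from compound 3 to compound 4 (0.42 log units; beyond the scatter), beyond the scatter. For compound 4 the expected half-life is 2 h, within a range from 0.8 h to 5 h, with a fair chance that only a limit is reported.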

Compound 4, half-life: 2.62 h
Estimate against measurement, compound 4: 1.3-fold (0.12 log units) below; low and high end bracket the measured number.
By their numbers in this assay, from the lowest: compounds 3 and 1 (each within the scatter of the next); then compound 4. At a limit, above all of these: compound 2.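

On the saturated chain carbon bound to an aromatic carbon and a saturated chain carbon, replacing 2,4-dioxo-1,3-thiazolidin-5-yl with the ring group that has one more double bond outside aromatic rings gives, in this assay, a 3.4-fold higher number from compound 3 to compound 4 (0.54 log units; beyond the scatter). Among these compounds, this is the first step that isolates a single change, and the counts of hydrogen-bond donors and acceptors stay the same across it. Compound 2 remains a limit and not a number, and it enters no step: the limit of > 3 h in this assay, at which 1 of the 4 values shown sits.

This one step cannot separate the added carbon from the added double bond, and no property of either group is measured. On these data alone, it also remains open how a carboxylic acid or an amine at this carbon would compare with compound 4 in this assay, and whether the step carries over to another core.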